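From a Difluorophenyl Ketone to a Hydroxyphenyl Ketone

A few compounds are considered here, and "the series" means these few. Any claim that something is new, unique, unknown or untested is made for them only; others in the source may bear on it.

Compound 1, `COc1cc(-c2nnc3n2NC(c2ccco2)C(C(=O)C2CC2)S3)cc(OC)c1OC`: in a functional assay on HepG2 cells (Homo sapiens) for cytotoxicity, read by MTT assay, with a stated time of 48 h (on this read-out higher numbers stand for weaker inhibition and lower numbers for stronger inhibition), compound 1 gives > 100000 nM, which is a limit of the assay.
Compound 2, `COc1cc(-c2nnc3n2NC(c2ccco2)C(C(=O)c2ccc(F)c(F)c2)S3)cc(OC)c1OC`: in this assay compound 2 gives 52400 nM.

Within the data shown here, compound 2 holds the only number in this assay, while the value of compound 1 is a limit (the limit of > 100000 nM in this assay, at which 1 of the 2 values shown sits). Among the measured compounds shown here, the one measured step, an at least 1.9-fold lower number from compound 1 to compound 2 (0.28 log units; that floor lies within the scatter), has a floor that lies within the scatter. Compound 3, `COc1cc(-c2nnc3n2NC(c2ccco2)C(C(=O)c2ccc(O)cc2)S3)cc(OC)c1OC`, carries the change (4-hydroxyphenyl in place of 3,4-difluorophenyl on a carbonyl carbon). For the measured compounds named here, only that step bears on it, and it sets no size beyond the scatter, so no shift beyond the scatter is expected in this assay. For compound 3 the expected step is a 1.3-fold higher number from compound 2 to compound 3 (0.13 log units; within the scatter). Compound 3 is estimated at 70000 nM, between 25000 nM and 200000 nM.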

Compound 3, half-maximal inhibitory concentration: > 100000 nM
Compound 3: no number, only a limit; the forecaster's own chance of this, stated with the estimate: 40%; middle value at least 1.4-fold (0.15 log units) from the limit.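

Compound 3 stands at a limit of the assay, not at a number, in this assay. The change to 4-hydroxyphenyl gives a step (an at least 1.9-fold higher number from compound 2 to compound 3 (0.28 log units; that floor lies within the scatter)) whose floor does not clear the scatter, so a six-membered aromatic ring on the carbonyl carbon does not by itself keep a compound off the limit. The step between the two limits cannot be read, and the limit now holds most of the values: the limit of > 100000 nM in this assay, at which 2 of the 3 values shown sit.

Open, going by these compounds, is how an amine or a carboxylic acid on that ring would read in this assay.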